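From 2-methoxybenzyl to 3-methoxybenzyl in the series

The source may hold more compounds than are shown below. What is called first, only, known or untested is meant among the compounds shown, and "the series" means these compounds.

Of the compounds shown here, two on the shared core have numbers so far. In a functional assay on K562 cells (Homo sapiens) for antiproliferative activity, with a stated time of 72 h (a higher number here means a weaker inhibitor, a lower number a stronger inhibitor), compound 1 `OC[C@H]1O[C@@H](n2cnc3c(NCc4ccc(Cl)cc4)ncnc32)[C@H](O)[C@@H]1O` gives 218000 nM, and compound 2 `COc1ccccc1CNc1ncnc2c1ncn2[C@@H]1O[C@H](CO)[C@@H](O)[C@H]1O` gives 89000 nM, the lower of the two numbers. For the measured compounds named here, the only measured step is a 2.4-fold lower number from compound 1 to compound 2 (0.39 log units; beyond the scatter), with 2-methoxyphenyl in place of 4-chlorophenyl on a saturated chain carbon bound to a nitrogen on an aromatic ring.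

Compound 3 `COc1cccc(CNc2ncnc3c2ncn3[C@@H]2O[C@H](CO)[C@@H](O)[C@H]2O)c1` is the next to be read. The change is 3-methoxyphenyl in place of 2-methoxyphenyl on a saturated chain carbon bound to a nitrogen on an aromatic ring: 3-methoxyphenyl in place of 2-methoxyphenyl at the same place, with the same atoms joined differently. Going by the values given here, no measured pair isolates this kind of change, so the evidence is indirect. The step to compound 2, a 2.4-fold lower number from compound 1 to compound 2 (0.39 log units; beyond the scatter), is modest and sets the likely scale, but it gives no direction for the new change. The expected step in this assay is therefore small, a 1.2-fold higher number from compound 2 to compound 3 (0.07 log units; within the scatter), with no shift beyond the scatter expected. For compound 3 the estimated value is 105000 nM, with an expected range of 45000 nM to 230000 nM.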

Compound 3, half-maximal inhibitory concentration: > 166000 nM
Compound 3: a limit, no number (the forecaster's own chance of this, stated with the estimate: 12%); middle value at least 1.5-fold (0.19 log units) from the limit.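

In this assay compound 3 gives > 166000 nM, which is a limit of the assay and not a number. For the compounds shown here, for the first time the series holds a pair with the same atoms joined differently, and 2-methoxybenzyl to 3-methoxybenzyl gives an at least 1.8-fold higher number from compound 2 to compound 3 (0.27 log units; that floor lies within the scatter), so this change at the same place can be read only as a floor, and that floor does not establish a shift beyond the scatter. The step between compound 1 and compound 3 cannot be read, and the reading of compound 3 ends at the limit: the limit of > 166000 nM in this assay, at which 1 of the 3 values shown sits.

The compounds shown leave open the actual value of compound 3, and so whether 3-methoxyphenyl truly differs from 2-methoxyphenyl by more than the scatter. Also open, from the compounds shown here alone, is how a benzyl carrying a hydroxyl or a carboxylic acid in place of the methoxy, or a phenethyl in place of the benzyl, would read on the shared core.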